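This account rests on a few compounds, and the source may have more. Where it says the series, first, only, none or still open, it means among the compounds named here.

Compound 2 `COc1cc(NCc2cccc(O)c2)cc(OC)c1OC` carries a hydrogen on the nitrogen that sits on its aromatic ring, and among the three measured compounds it stands highest, that is weakest: in a functional assay on MGC-803 cells (Homo sapiens) for inhibition, read by MTT assay, with a stated time of 48 h (a lower number here means a stronger inhibitor, a higher number a weaker inhibitor), compound 2 gives 57600 nM. Compound 1 `C/C=C/C(=O)N(Cc1cccc(O)c1)c1cc(OC)c(OC)c(OC)c1` carries a (prop-1-en-1-yl)carbonyl on that nitrogen instead, and compound 1 gives 14100 nM; the step of a 4.1-fold higher number from compound 1 to compound 2 (0.61 log units; beyond the scatter) shows the cost of removing that group. Compound 3 `C/C=C/C(=O)N(Cc1ccc(OC)cc1)c1cc(OC)c(OC)c(OC)c1` keeps the carbonyl but bears a 4-methoxyphenyl, and compound 3 gives 450 nM, so that a 31-fold lower number from compound 1 to compound 3 (1.50 log units; beyond the scatter).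

Compound 4 `COc1cc(NCc2ccc(C)cc2)cc(OC)c1OC` is not yet measured and differs from compound 2 in one place: 4-methylphenyl in place of 3-hydroxyphenyl on a saturated chain carbon bound to a nitrogen on an aromatic ring. Going by the values given here, no measured step matches this change exactly, but the step from compound 1 to compound 3 also removed a 3-hydroxyphenyl and was large. Because a 31-fold lower number from compound 1 to compound 3 (1.50 log units; beyond the scatter) was large, a lower number is expected for compound 4. With a methyl rather than a methoxy, and on the free amine, only a smaller step is expected for compound 4, namely the estimated 7.2-fold lower number from compound 2 to compound 4 (0.86 log units; beyond the scatter). Compound 4 is therefore estimated at 8000 nM, with a likely range from 2000 nM to 30000 nM.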

Compound 4, half-maximal inhibitory concentration: > 80000 nM
Compound 4 gave a limit, no number (the forecaster's own chance of this, stated with the estimate: 5%); middle value at least 10-fold (1.00 log units) from the limit.
By their numbers in this assay, from the lowest: compound 3; then compound 1; then compound 2. At a limit, above all of these: compound 4.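

In this assay, compound 4 gives only a limit of the assay, not a number: the limit of > 80000 nM in this assay, at which 1 of the 4 values shown sits. On these data alone, the step therefore reads an at least 1.3-fold higher number from compound 2 to compound 4 (0.14 log units; that floor lies within the scatter), so its true size is unknown, and this floor alone does not separate the two compounds. Even so, replacing 3-hydroxyphenyl on the free amine brings no sign of the strengthening seen with the (prop-1-en-1-yl)carbonyl on the nitrogen, a 31-fold lower number from compound 1 to compound 3 (1.50 log units; beyond the scatter), although that step brought in 4-methoxyphenyl rather than 4-methylphenyl.

The compounds shown leave open whether the difference comes from the group on the nitrogen or from methyl versus methoxy, since neither 4-methylphenyl with the carbonyl nor 4-methoxyphenyl on the free amine appears here. As far as these compounds go, how a 4-chlorophenyl or 4-aminophenyl would read at this position also remains open.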